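Chlorine Position on the Aryl Group of Three Nucleosides

The source may report more compounds than this note shows. Statements on the series, on what has been measured and on what is new or still open speak of the compounds shown alone.

In a functional assay on NCI-H460 cells (Homo sapiens) for antiproliferative activity, with a stated time of 72 h (a higher number here means a weaker inhibitor, a lower number a stronger inhibitor), three compounds have been measured:

Compound 1, `Nc1ncnn2c([C@@H]3O[C@H](CO)[C@@H](O)[C@H]3O)cc(C#Cc3ccccc3)c12`: 38500 nM
Compound 2, `Nc1ncnn2c([C@@H]3O[C@H](CO)[C@@H](O)[C@H]3O)cc(-c3ccc(F)cc3)c12`: 55500 nM
Compound 3, `Nc1ncnn2c([C@@H]3O[C@H](CO)[C@@H](O)[C@H]3O)cc(-c3ccc(Cl)cc3)c12`: 45900 nM

Compound 3 holds the second highest of the three numbers. The step of a 1.2-fold higher number from compound 1 to compound 3 (0.08 log units; within the scatter) is its closer pairing and a 1.2-fold lower number from compound 2 to compound 3 (0.08 log units; within the scatter) the wider one, and both lie within the scatter, so the three compounds cannot be ordered.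

Compound 4, `Nc1ncnn2c([C@@H]3O[C@H](CO)[C@@H](O)[C@H]3O)cc(-c3ccccc3Cl)c12`, carries the change (2-chlorophenyl in place of 4-chlorophenyl on an aromatic carbon). Going by the values given here, no measured step moves a chlorine around the ring. Among the compounds with values here, the steps that bear on it exchange the whole group: a 1.4-fold higher number from compound 1 to compound 2 (0.16 log units; within the scatter) and a 1.2-fold higher number from compound 1 to compound 3 (0.08 log units; within the scatter), both within the scatter. The expected step is therefore none beyond the scatter, a 1.0-fold higher number from compound 3 to compound 4 (0.00 log units; within the scatter). For compound 4 the estimate is 46000 nM, in a range from 20000 nM to 100000 nM.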

Compound 4, half-maximal inhibitory concentration: > 100000 nM
Compound 4 was reported as a limit (the forecaster's own chance of this, stated with the estimate: 15%); at least 2.1-fold (0.33 log units) between middle value and limit.
By their numbers in this assay, from the lowest: compounds 1, 3 and 2 (each within the scatter of the next). At a limit, above all of these: compound 4.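

Across the aryl groups at this position, the earlier steps in this assay all stayed within the scatter, whereas moving the chlorine gives a step beyond it (an at least 2.1-fold higher number from compound 3 to compound 4 (0.33 log units; beyond the scatter)), as does the exchange of 2-phenylethynyl for 2-chlorophenyl (an at least 2.5-fold higher number from compound 1 to compound 4 (0.41 log units; beyond the scatter)). The comparison with the 4-fluorophenyl group is less clear (an at least 1.8-fold higher number from compound 2 to compound 4 (0.25 log units; that floor lies within the scatter)). Compound 4 stands at a limit of the assay, not at a number: the limit of > 100000 nM in this assay, at which 1 of the 4 values shown sits.

On these data alone, what an amine or a carboxylic acid in place of the chlorine would do stays open. The compounds shown also do not tell why the place of the chlorine matters.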